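A few compounds are considered here, and "the series" means these few. Any claim that something is new, unique, unknown or untested is made for them only; others in the source may bear on it.

Measured so far, in a functional assay on Shh Light II cells (Mus musculus) for inhibition, read by a luciferase reporter; a lower number here means a stronger inhibitor, a higher number a weaker inhibitor:

Compound 1 `Cc1noc(C)c1NC(=O)N1CCC(c2nc(-c3ccc4ccccc4n3)no2)CC1` gives 3000 nM.
Compound 2 `Cc1ccccc1NC(=O)N1CCC(c2nc(-c3ccc4ccccc4n3)no2)CC1` gives 440 nM.
Compound 3 `O=C(CC1CCCCCC1)N1CCC(c2nc(-c3ccc4ccccc4n3)no2)CC1` gives 840 nM.

Compound 3 stands second highest of the three numbers. Its nearest neighbour is compound 2, reached by a 1.9-fold higher number from compound 2 to compound 3 (0.28 log units; within the scatter), a gap that stays within the scatter. The furthest is compound 1, reached by a 3.6-fold lower number from compound 1 to compound 3 (0.55 log units; beyond the scatter).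

Compound 4 `CC(=O)N1CCC(NC(=O)N2CCC(c3nc(-c4ccc5ccccc5n4)no3)CC2)CC1` is not yet measured. It differs from compound 3 in one place: (1-acetylpiperidin-4-yl)amino in place of cycloheptylmethyl on a carbonyl carbon.

Among the compounds with values here, two measured steps touch the same carbonyl carbon. The step of a 3.6-fold lower number from compound 1 to compound 3 (0.55 log units; beyond the scatter) shows that exchanging a (3,5-dimethyl-1,2-oxazol-4-yl)amino for a cycloheptylmethyl lowered the number clearly, while a 1.9-fold higher number from compound 2 to compound 3 (0.28 log units; within the scatter) shows the exchange from (2-methylphenyl)amino did not move it beyond the scatter. Compound 4 returns to an amino substituent on that carbonyl carbon, as in compounds 1 and 2, but with a non-aromatic 1-acetylpiperidin-4-yl group, for which no measured comparison exists. Given the two amino-bearing compounds span the whole range seen so far, a modest move upward from compound 3 is expected, with wide uncertainty: a 1.8-fold higher number from compound 3 to compound 4 (0.25 log units; within the scatter). Compound 4 is therefore estimated at 1500 nM, within a range from 400 nM to 6000 nM.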

Compound 4, half-maximal inhibitory concentration: 500 nM
Beside the measured number, compound 4's estimate is 3.0-fold (0.48 log units) above it, within the range that was stated.
By their numbers in this assay, from the lowest: compounds 2, 4 and 3 (each within the scatter of the next); then compound 1.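

In this assay the exchange of cycloheptylmethyl for (1-acetylpiperidin-4-yl)amino on the carbonyl carbon, a 1.7-fold lower number from compound 3 to compound 4 (0.23 log units; within the scatter), stays within the scatter, so a group with a hydrogen-bond donor and acceptor reads the same here as a carbon-only group without them. Within the data shown here, on the amide-type nitrogen, a 1.1-fold higher number from compound 2 to compound 4 (0.06 log units; within the scatter) is also within the scatter, which shows that a non-aromatic ring can stand in for 2-methylphenyl, while a 6.0-fold lower number from compound 1 to compound 4 (0.78 log units; beyond the scatter) confirms that 3,5-dimethyl-1,2-oxazol-4-yl is the only group so far that stands apart, as the weakest of the four. No measurement shown offers any explanation for these steps.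

The compounds shown leave open what the acetyl contributes, as a free piperidin-4-yl amine or a methanesulfonyl group on that ring nitrogen would test this directly. They also leave open how a carboxylic acid or a longer chain on the carbonyl carbon would read in this assay against the groups seen so far.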